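A Chloro Step Tested for Cytotoxicity on Mouse Cells

A few compounds are considered here, and "the series" means these few. Any claim that something is new, unique, unknown or untested is made for them only; others in the source may bear on it.

Measured so far:
Compound 1, `COc1ccccc1S(=O)(=O)/C=C/c1ccccn1`: 100%
Compound 2, `COc1ccccc1S(=O)(=O)/C=C/c1ccc(Cl)cn1`: 100%
Compound 3, `COc1ccc(S(=O)(=O)/C=C/c2ccccn2)cc1`: 100%

All three were tested in an ADME assay on BV-2 cells (Mus musculus) for cytotoxicity, with a stated time of 24 h, tested at 10 uM; a higher number here means a weaker effect of the compound at the concentration tested, a lower number a stronger effect. Compound 2 differs from compound 1 by chloro in place of hydrogen on an aromatic carbon, and the step of no change at the digits printed from compound 1 to compound 2 (within the scatter) shows that this addition left the read-out unchanged within the scatter. Compound 3 has the same atoms as compound 1 joined differently; the difference between the two cores is not broken down here. In this assay compound 3 stands level with compounds 1 and 2 within the scatter.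

Compound 4, `COc1ccc(S(=O)(=O)/C=C/c2cccc(Cl)n2)cc1`, has not been measured. It differs from compound 3 by chloro in place of hydrogen on an aromatic carbon. Within the data shown here, this is the same kind of change as the one from compound 1 to compound 2, but the place differs: in compound 2 the chloro sits two atoms from the ring nitrogen and para to a large group, while in compound 4 it sits next to the ring nitrogen and meta to a large group. Because no change at the digits printed from compound 1 to compound 2 (within the scatter) showed no change, the step from compound 3 to compound 4 is expected to be no change at the digits printed from compound 3 to compound 4 (within the scatter). Compound 4 is therefore estimated at 100%, with a likely range from 88% to 100%.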

Compound 4, a percentage reported as activity, at one concentration (the size of the read-out at that concentration, not a potency): 97%
The estimate for compound 4 lay 3 percentage points above the measured number; measured number inside the range.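

In this assay, chloro in place of hydrogen on an aromatic carbon gave a number 3 percentage points lower from compound 3 to compound 4 (within the scatter), so on this second core the change again stayed within the usual scatter. Setting the two steps side by side shows that they agree: the same change on two cores in this assay, no change at the digits printed (within the scatter) from compound 1 to compound 2 and a number 3 percentage points lower (within the scatter) from compound 3 to compound 4, 3 percentage points apart, within the scatter of two such steps This suggests that, for these two pairs, the change can be carried from one core to the other with little effect on this read-out, but it does not show that this would hold for chloro at other places on the ring, on other cores, or at other concentrations, and the chloro sits at a different place in each pair, so position and core are not separated.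

The compounds shown leave open what a different group in the same place, such as an amine, a carboxylic acid or a longer chain, would do to this read-out. They also leave open whether any change in this series would give a clearly stronger effect on these cells.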